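Trifluoromethyl to Hydrogen on an Aromatic Oxygen

The source may report more compounds than this note shows. Statements on the series, on what has been measured and on what is new or still open speak of the compounds shown alone.

Measured so far:
- compound 1, `CCc1nc(-c2ccc(OC)cc2OC(F)(F)F)c(CC)nc1NC(CC)CC`: 0.267 h
- compound 2, `CCc1nc(NC(CC)CC)cnc1-c1ccc(Cl)cc1Cl`: 0.467 h

Among the measured compounds shown here, in an in vitro ADME assay on microsomes (Homo sapiens) for metabolic stability (on this read-out lower numbers stand for a shorter-lived compound and higher numbers for a longer-lived compound), compound 1 gives 0.267 h, the lower of the two numbers known. Compound 2 gives 0.467 h, and the two values lie within the scatter of each other, so neither compound can be called longer- or shorter-lived than the other. Compound 3, `CCc1nc(-c2ccc(OC)cc2O)c(CC)nc1NC(CC)CC`, has not yet been measured. It differs from compound 1 in one place: hydrogen in place of trifluoromethyl on an oxygen on an aromatic ring. For the measured compounds named here, no pair of measured compounds carries this change, so nothing measured here tells how large a step it brings; the expectation below rests on compound 1 alone. The step of a 1.1-fold higher number from compound 1 to compound 3 (0.05 log units; within the scatter) is expected to be none beyond the scatter, in either direction. In this assay compound 3 is therefore expected to give about 0.3 h, with a range from 0.12 h to 0.8 h.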

Compound 3, half-life: 0.3 h
Compound 3: the middle estimate sits on the measured number at the digits printed; the measured number falls inside the stated range.
By their numbers in this assay, from the lowest: compounds 1, 3 and 2 (each within the scatter of the next).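

In this assay, putting hydrogen in place of trifluoromethyl on this oxygen on an aromatic ring gives a 1.1-fold higher number from compound 1 to compound 3 (0.05 log units; within the scatter). Among the compounds shown here, this pair is the first direct reading of the change, and it shows that, in this core, trifluoromethoxy and hydroxy at this place cannot be told apart on this read-out, even though the whole trifluoromethyl group is gone. Nothing shown here offers an explanation for this outcome.

What the compounds shown leave open is whether other groups on the same oxygen, such as a methyl, a longer chain or a group carrying an amine, would also stay within the scatter of compound 1. One pair also cannot say whether the same change would give a similar step on a different core.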